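Methyl Ester in Place of Acid: Maximal Response Compared

The compounds below may be only part of what the source reports. "The series", "measured", "known", "first", "only" and "open" are said of these compounds alone.

Three compounds were measured in an assay on HEK293 cells for positive allosteric modulation of metabotropic glutamate receptor 2 (Rattus norvegicus), read by thallium flux, with a stated time of 2.5 min; a lower number here means a smaller maximal response, a higher number a larger maximal response. Compound 1 `COC(=O)c1ccc(OCCCCOc2ccc(C(=O)CC3CCCC3)c(C)c2C)cc1` gives 14.1%. Compound 2 `Cc1c(OCCCCOc2ccc(C(=O)O)cc2)ccc(C(=O)CC2CCCC2)c1C` gives 16.2%. Compound 3 `Cc1c(OCCCCOc2ccc(C(=O)O)cc2)ccc(C(=O)CC(C)C)c1O` gives 88%, the highest of the three numbers; compound 2 stands nearest below it and compound 1 furthest below it, both gaps lying beyond the scatter.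

Compound 1 and compound 2 differ in a single place: methyl in place of hydrogen on an oxygen next to a carbonyl group. In this assay this change gave a number 2.1 percentage points lower from compound 2 to compound 1 (within the scatter). Compound 3 and compound 2 are not related by one counted change, and the difference between the two cores is not broken down here.

Compound 4 `COC(=O)c1ccc(OCCCCOc2ccc(C(=O)CC(C)C)c(O)c2C)cc1` has not yet been measured. For the measured compounds named here, it differs from compound 3 by methyl in place of hydrogen on an oxygen next to a carbonyl group, and this is the same change as the one that leads from compound 2 to compound 1, the place being described in identical words in both cases. Within the compounds shown the change occurs two times in all. In this assay the step expected for compound 4 is a number 5 percentage points lower from compound 3 to compound 4 (within the scatter), set beside the measured a number 2.1 percentage points lower from compound 2 to compound 1 (within the scatter). This expectation rests on that one measured occurrence, which stayed within the scatter on a different core, and on compound 3 holding the highest number seen. Compound 4 is therefore estimated at 83%, with a likely range from 66% to 96%.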

Compound 4, largest response reached (reported as percent of maximum), in percent of the reference or control that the assay uses: 16.4%
Estimate against measurement, compound 4: 66.6 percentage points above; measured number outside the range, below it.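

In this assay, methyl in place of hydrogen on an oxygen next to a carbonyl group, which turns carboxy into methoxycarbonyl, gave a number 71.6 percentage points lower from compound 3 to compound 4 (beyond the scatter) on the core of compound 3, so the change that had made no readable difference on the other core made a large one here. The size of this step therefore did not carry from one core to the other, and a step measured on one core in this series gives no safe guide to the step on another: the same change on two cores in this assay, a number 2.1 percentage points lower (within the scatter) from compound 2 to compound 1 and a number 71.6 percentage points lower (beyond the scatter) from compound 3 to compound 4, 69.5 percentage points apart, beyond the scatter of two such steps. For the compounds shown here, with only two occurrences of the change, and with compound 2 and compound 3 not related by one counted change, this shows that the outcome depends on the core but not which feature of the core decides it, and it gives no cause for the difference.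

The compounds shown leave open whether an ethyl ester, a primary amide or a tetrazole in place of the carboxy on the core of compound 3 would stay close to compound 3 or fall close to compound 4. They also leave open whether the same change would give a large step or a small one on further cores, for instance one that carries a longer chain between the two ether oxygens.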